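The source may hold more compounds than are shown below. What is called first, only, known or untested is meant among the compounds shown, and "the series" means these compounds.

Compound 1 `Nc1scc(CN2CCN(c3cccc(Cl)c3Cl)CC2)c1C(=O)c1ccc(Cl)cc1`: -57%
Compound 2 `Nc1scc(CN2CCN(c3cc(Cl)cc(Cl)c3)CC2)c1C(=O)c1ccc(Cl)cc1`: -69%
Compound 3 `COc1ccc(N2CCN(Cc3csc(N)c3C(=O)c3ccc(Cl)cc3)CC2)cc1`: -15%

In a functional assay on CHO cells with adenosine receptor A1 (Homo sapiens) as the target, read by cAMP accumulation and immunoassay, with a stated time of 6 min, tested at 1 uM (a higher number here means a weaker effect of the compound at the concentration tested, a lower number a stronger effect), compound 3 gives -15%, the highest of the three numbers, so the weakest effect of the set. The step of a number 42 percentage points higher from compound 1 to compound 3 (beyond the scatter) and the step of a number 54 percentage points higher from compound 2 to compound 3 (beyond the scatter) both lie beyond the scatter and are large, while the step of a number 12 percentage points lower from compound 1 to compound 2 (beyond the scatter) between the two dichlorophenyl compounds is only modest.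

Compound 4 `Nc1scc(CN2CCN(c3ccc(Cl)c(C(F)(F)F)c3)CC2)c1C(=O)c1ccc(Cl)cc1` has not yet been measured in this assay. It differs from compound 3 in one place: 4-chloro-3-(trifluoromethyl)phenyl in place of 4-methoxyphenyl on an amine nitrogen in a ring. Among the compounds with values here, the steps that bear on this change are those from compound 1 and compound 2 to compound 3, where a chlorine-bearing phenyl gave way to 4-methoxyphenyl and the number rose by a large amount. Compound 4 brings a chlorine-bearing phenyl back, so the step from compound 3 to compound 4 is expected to run the other way, large and downward, as a number 45 percentage points lower from compound 3 to compound 4 (beyond the scatter). Compound 4 is therefore estimated to give -60%, within the range -80% to -35%.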

Compound 4, a percentage reported as activity, at one concentration (the size of the read-out at that concentration, not a potency): -47%
Beside the measured number, compound 4's estimate is 13 percentage points below it; the measured number falls inside the stated range.
By their numbers in this assay, from the lowest: compound 2; then compounds 1 and 4 (each within the scatter of the next); then compound 3.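

In this assay, 4-chloro-3-(trifluoromethyl)phenyl in place of 4-methoxyphenyl on the amine nitrogen in a ring gives a number 32 percentage points lower from compound 3 to compound 4 (beyond the scatter), so the low numbers at this position are not confined to the two dichlorophenyl groups. Against 2,3-dichlorophenyl the new group shows a number 10 percentage points higher from compound 1 to compound 4 (within the scatter), which leaves the two indistinguishable, while against 3,5-dichlorophenyl it shows a number 22 percentage points higher from compound 2 to compound 4 (beyond the scatter), so the kind of substitution on the phenyl still matters among the halogen-bearing groups. Nothing available here accounts for these differences.

From the compounds shown here alone, it remains open whether a phenyl carrying only a chlorine or only a trifluoromethyl would give a number this low. Also open, going by these compounds, is how a phenyl carrying a nitrile or a carboxylic acid would behave at this place.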